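The source may hold more compounds than are shown below. What is called first, only, known or untested is meant among the compounds shown, and "the series" means these compounds.

Measured so far:
- compound 1 `C#Cc1cccc(Nc2ncnc3cc(OC)c(OCCCCC(=O)Nc4ccc(S(N)(=O)=O)cc4)cc23)c1` gives 17700 nM in a functional assay on A-431 cells (Homo sapiens) for antiproliferative activity, read by MTT assay, with a stated time of 72 h; on this read-out lower numbers stand for stronger inhibition and higher numbers for weaker inhibition
- compound 2 `COc1cc2ncnc(Nc3cccc(F)c3)c2cc1OCCCCC(=O)Nc1ccc(S(N)(=O)=O)cc1` gives 29900 nM in this assay
- compound 3 `COc1ccc(Nc2ncnc3cc(OC)c(OCCCCC(=O)Nc4ccc(S(N)(=O)=O)cc4)cc23)cc1OC` gives 35400 nM in this assay

Compound 3 carries the largest of the three numbers as read, but its separation from the others is no more than scatter: the step of a 1.2-fold higher number from compound 2 to compound 3 (0.07 log units; within the scatter) and the step of a 2.0-fold higher number from compound 1 to compound 3 (0.30 log units; within the scatter) are both within it, so no ordering among compounds 1, 2 and 3 is claimed.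

Compound 4 `COc1cc2ncnc(Nc3ccc(F)c(Br)c3)c2cc1OCCCCC(=O)Nc1ccc(S(N)(=O)=O)cc1` is the next member. It differs from compound 3 only at the aniline: 3-bromo-4-fluorophenyl in place of 3,4-dimethoxyphenyl on a nitrogen on an aromatic ring.

For the measured compounds named here, the steps that bear on this change are the earlier swaps of the same aryl group on the same nitrogen: a 2.0-fold higher number from compound 1 to compound 3 (0.30 log units; within the scatter), a 1.2-fold higher number from compound 2 to compound 3 (0.07 log units; within the scatter) and a 1.7-fold higher number from compound 1 to compound 2 (0.23 log units; within the scatter). All three lie within the scatter, whatever the aryl substituent. The shared core with its long amide-linked sulfonamide chain appears to set the number, and the aryl group has not moved it so far. For compound 4 the expected step is therefore a 1.3-fold lower number from compound 3 to compound 4 (0.10 log units; within the scatter), none beyond the scatter. Compound 4 is expected to give 28000 nM in this assay, estimated between 11000 nM and 70000 nM.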

Compound 4, half-maximal inhibitory concentration: 8020 nM
Compound 4: middle estimate off by 3.5-fold (0.54 log units), on the high side, and the stated range ends above it.
By their numbers in this assay, from the lowest: compound 4; then compounds 1, 2 and 3 (each within the scatter of the next).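

In this assay the aryl group on a nitrogen on an aromatic ring can move the number: 3-bromo-4-fluorophenyl gives a 4.4-fold lower number from compound 3 to compound 4 (0.64 log units; beyond the scatter) and a 3.7-fold lower number from compound 2 to compound 4 (0.57 log units; beyond the scatter) and also a 2.2-fold lower number from compound 1 to compound 4 (0.34 log units; beyond the scatter) with all three steps modest, whereas swaps among the three earlier aryl groups stayed within the scatter. The shared core with its amide-linked sulfonamide chain therefore does not set the number alone, and compound 4 stands apart from compound 1, compound 2 and compound 3. Nothing at hand explains why this aryl group differs from the others.

Open, from the compounds shown here alone, is whether a 3-bromophenyl or a 4-fluorophenyl group alone would give the same step. Also open, going by these compounds, is whether the step would hold with a shorter chain or with a carboxylic acid in place of the sulfonamide.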